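The source may hold more compounds than are shown below. What is called first, only, known or untested is meant among the compounds shown, and "the series" means these compounds.

Measured compounds:
compound 1 `COc1ccc([C@@H]2C/C(=N\O)c3c(O)cc(OCc4cn(Cc5ccccc5F)nn4)cc3O2)cc1O` — 5710 nM in a functional assay on RAW264.7 cells (Mus musculus) for inhibition, read by Griess assay, with stated times of 2 h and 24 h; a higher number here means a weaker inhibitor, a lower number a stronger inhibitor
compound 2 `CCCCn1cc(COc2cc(O)c3c(c2)O[C@H](c2ccc(OC)c(O)c2)C/C3=N\O)nn1` — 8900 nM
compound 3 `COc1ccc([C@@H]2CC(=O)c3c(O)cc(OCc4cn(CC5CC5)nn4)cc3O2)cc1O` — 11900 nM

Compound 3 gives the highest of the three numbers in this assay. Its nearest neighbour is compound 2, whose number is lower by an amount within the scatter, so the two cannot be ordered; against compound 1 the gap is beyond the scatter, and compound 1 gives the lower number. Among the measured compounds shown here, compound 3 also carries a carbonyl in the core where compound 1 and compound 2 carry an oxime, so no single step links it to either.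

Compound 4 `COc1ccc([C@@H]2CC(=O)c3c(O)cc(OCc4cn(Cc5cccc(C(F)(F)F)c5)nn4)cc3O2)cc1O` is not yet measured. It differs from compound 3 by 3-(trifluoromethyl)phenyl in place of cyclopropyl on a saturated chain carbon bound to an aromatic nitrogen.

For the measured compounds named here, one measured step bears on this change: a 1.6-fold higher number from compound 1 to compound 2 (0.19 log units; within the scatter), the exchange of an aromatic group for an alkyl group at the same place. It sat within the scatter. The move from compound 3 to compound 4 runs the other way, from alkyl to aromatic, so any shift is expected to be small and, if anything, toward a lower number.

Compound 4 is expected to give about 8000 nM in this assay, within 3500 nM to 18000 nM, meaning an expected step of a 1.5-fold lower number from compound 3 to compound 4 (0.17 log units; within the scatter).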

Compound 4, half-maximal inhibitory concentration: 19900 nM
The estimate for compound 4 lay 2.5-fold (0.40 log units) below the measured number; the measured number lies above the stated range.
By their numbers in this assay, from the lowest: compounds 1, 2, 3 and 4 (each within the scatter of the next, the first and the last beyond it).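

In this assay, a 1.7-fold higher number from compound 3 to compound 4 (0.22 log units; within the scatter), so on the carbonyl core, replacing cyclopropyl (3 heavy atoms) with 3-(trifluoromethyl)phenyl (10 heavy atoms) on a saturated chain carbon bound to an aromatic nitrogen gives no readable change. The oxime pair had already given a 1.6-fold higher number from compound 1 to compound 2 (0.19 log units; within the scatter), and with the carbonyl pair now read as well, an exchange between an aromatic and a non-aromatic group at this place stays within the scatter on both cores, though the two pairs carry different groups and neither step sets a direction. No supporting measurement is available to account for this tolerance of the position.

The compounds shown leave open whether a group of another kind at this place, such as an amine or a carboxylic acid, would move the number beyond the scatter. Among the compounds shown here, they also hold no pair with the same group on the oxime and carbonyl cores, so what the exchange of carbonyl for oxime does on its own remains unread in this assay.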